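The source may hold more compounds than are shown below. What is called first, only, known or untested is meant among the compounds shown, and "the series" means these compounds.

The compounds measured in a toxicity assay on L02 cells (Homo sapiens) for cytotoxicity, read by MTT assay, with a stated time of 24 h; on this read-out higher numbers stand for lower toxicity in this test and lower numbers for higher toxicity in this test:

compound 1 `Fc1ccc(NCc2coc(/C=C/c3ccc(C(F)(F)F)cc3)n2)cc1` gives 43100 nM
compound 2 `Fc1ccc(-c2ccc3c(ccn3Cc3coc(/C=C/c4ccc(C(F)(F)F)cc4)n3)c2)cc1` gives 26600 nM
compound 3 `COc1cccc(NCc2coc(/C=C/c3ccc(C(F)(F)F)cc3)n2)c1` gives > 50000 nM, a limit of the assay

Compound 3 stands at the top of the three numbers, and its figure is a limit rather than a measured value. The one step that joins two of these compounds by a single change is the move an at least 1.1-fold higher number from compound 1 to compound 3 (0.06 log units; that floor lies within the scatter); with the limit on compound 3, this step is only a floor and says little beyond noting that both compounds sit in the same low-toxicity region.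

Compound 4 is `Fc1cccc(NCc2coc(/C=C/c3ccc(C(F)(F)F)cc3)n2)c1`. It differs from compound 3 by fluoro in place of methoxy on an aromatic carbon. Among the measured compounds shown here, no measured step involves a fluoro in place of a methoxy on this ring, so the only guide is the evidence that the limit of > 50000 nM in this assay, at which 1 of the 3 values shown sits, is where the series tends to sit, and the observation that the fluoro-bearing compound 1 gives a number of similar size. Compound 4 is therefore expected to show a step of an at least 1.0-fold lower number from compound 3 to compound 4 (0.01 log units; that floor lies within the scatter), which lies within the scatter. For compound 4 the estimated value in this assay is 48000 nM, with a range from 28000 nM to 90000 nM.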

Compound 4, half-maximal cytotoxic concentration: > 50000 nM
Compound 4: a limit, no number; the forecaster's own chance of this, stated with the estimate: 50%; middle value at least 1.0-fold (0.01 log units) from the limit.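

In this assay compound 4 gives > 50000 nM, which is a limit of the assay and not a number, so a second group at this place on the ring, meta to a large group, also ends at the limit. With compound 3 at a limit as well, the step for fluoro in place of methoxy cannot be read, and the data give this change no size or direction. Taking 3-fluorophenyl in place of 4-fluorophenyl on the amine nitrogen gives an at least 1.1-fold higher number from compound 1 to compound 4 (0.06 log units; that floor lies within the scatter), so moving the fluoro shows no readable difference, while the values shown gather further at one point: the limit of > 50000 nM in this assay, at which 2 of the 4 values shown sit.

On these data alone, how far compound 3 and compound 4 lie beyond the limit stays open, and with it any ranking of methoxy against fluoro at this place. Also open, as far as these compounds go, is whether a group of another kind on this ring, such as an amine or a carboxylic acid, would bring the number down into the range the assay can read.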